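Sulfonyl substituent variation in a prostaglandin D2 receptor 2 series

A few compounds are considered here, and "the series" means these few. Any claim that something is new, unique, unknown or untested is made for them only; others in the source may bear on it.

Measured compounds:
compound 1 `Cc1ccc(S(=O)(=O)Cc2ccccc2)cc1C#Cc1cc(Cl)ccc1OCC(=O)O`, 5 nM
compound 2 `Cc1ccc(S(=O)(=O)N2CCOCC2)cc1C#Cc1cc(Cl)ccc1OCC(=O)O`, 3.6 nM

In an assay on CHO cells for displacement of a labelled ligand from prostaglandin D2 receptor 2 (Homo sapiens), read by scintillation counting (on this read-out higher numbers stand for weaker inhibition and lower numbers for stronger inhibition), compound 2 gives 3.6 nM, the lowest of the two numbers, though the step of a 1.4-fold lower number from compound 1 to compound 2 (0.14 log units; within the scatter) lies within the scatter. Compound 3 `Cc1ccc(S(=O)(=O)NC(C)(C)C)cc1C#Cc1cc(Cl)ccc1OCC(=O)O` differs from compound 2 by (tert-butyl)amino in place of morpholin-4-yl on a sulfonyl sulfur. Among the measured compounds shown here, the only measured step at this position, a 1.4-fold lower number from compound 1 to compound 2 (0.14 log units; within the scatter), barely moved the number, so no step beyond the scatter is expected for compound 3 in this assay. Compound 3 is therefore estimated at 5 nM, with a range of 2 nM to 15 nM, meaning an expected step of a 1.4-fold higher number from compound 2 to compound 3 (0.14 log units; within the scatter).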

Compound 3, inhibition constant: 5 nM
Compound 3: the middle estimate sits on the measured number at the digits printed, within the range that was stated.
By their numbers in this assay, from the lowest: compounds 2, 1 and 3 (each within the scatter of the next).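

In this assay the sulfonyl sulfur also accepts an open-chain amine substituent, with a 1.4-fold higher number from compound 2 to compound 3 (0.14 log units; within the scatter) and no change at the digits printed from compound 1 to compound 3 (within the scatter). Losing the morpholin-4-yl ring and gaining a hydrogen-bond donor in (tert-butyl)amino therefore gives no step beyond the scatter, and the benzyl, morpholin-4-yl and (tert-butyl)amino compounds cannot be ranked. No evidence available here bears on this result. Still open, on these data alone, is whether a plain amino group or a piperidin-1-yl group on the sulfonyl sulfur would also stay within the scatter. Changes elsewhere on the shared core also remain untested by these compounds.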